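This account rests on a few compounds, and the source may have more. Where it says the series, first, only, none or still open, it means among the compounds named here.

Compound 1 `CSc1nc2sncc2n1[C@H]1C[C@H](O)[C@@H](CO)O1` and compound 2 `OC[C@H]1O[C@@H](n2c(SCc3ccccc3)nc3sncc32)C[C@@H]1O` share one core, while compound 3 `CSc1nc2c(C)nsc2n1[C@@H]1O[C@H](CO)[C@@H](O)[C@@H]1O` rests on another; the difference between the two cores is not broken down here. In a functional assay on L1210 cells (Mus musculus) for antiproliferative activity (on this read-out higher numbers stand for weaker inhibition and lower numbers for stronger inhibition), compound 1 gives 20000 nM. In this assay compound 2 gives 2200 nM. The change from compound 1 to compound 2 is phenyl in place of hydrogen on a saturated chain carbon bound to a sulfur, and it brought a 9.1-fold lower number from compound 1 to compound 2 (0.96 log units; beyond the scatter). For compound 3 the this assay reports only a limit, > 100000 nM. Among the compounds with values here, it is the one value among the three that sits at the limit of > 100000 nM in this assay, at which 1 of the 3 values shown sits.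

Compound 4 `Cc1nsc2c1nc(SCc1ccccc1)n2[C@@H]1O[C@H](CO)[C@@H](O)[C@@H]1O` has not yet been measured in this assay. It carries the same change relative to compound 3, (phenyl in place of hydrogen on a saturated chain carbon bound to a sulfur), at the same place as before. Within the data shown here, because a 9.1-fold lower number from compound 1 to compound 2 (0.96 log units; beyond the scatter) was made on a different core and is the only example of this change with two measured ends, a step of similar size is expected from compound 3 to compound 4, while the limit of compound 3 leaves the starting point open. The step from compound 3 to compound 4 in this assay is estimated as an at least 3.3-fold lower number from compound 3 to compound 4 (0.52 log units; beyond the scatter). Compound 4 is expected to give about 30000 nM in this assay, with a range from 8000 nM to 200000 nM, and it may well come back as a limit again.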

Compound 4, half-maximal inhibitory concentration: > 100000 nM
Compound 4 ended at the assay's limit (the forecaster's own chance of this, stated with the estimate: 45%); middle value at least 3.3-fold (0.52 log units) from the limit.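

In this assay compound 3 gives > 100000 nM, which is a limit. Compound 4 gives > 100000 nM, also a limit. No step can be read from compound 3 to compound 4, as both stand at the same limit: the limit of > 100000 nM in this assay, at which 2 of the 4 values shown sit. The compounds shown leave open whether the change from methylsulfanyl to benzylsulfanyl shifts the number at all on the core of compound 3.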